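The source may hold more compounds than are shown below. What is called first, only, known or untested is meant among the compounds shown, and "the series" means these compounds.

Measured compounds in a functional assay on HeLa cells (Homo sapiens) for cytotoxicity, read by MTT assay, with a stated time of 48 h; a lower number here means a stronger inhibitor, a higher number a weaker inhibitor:

Compound 1 `COc1ccc(OC(=O)c2cn(-c3ccccc3)nc2-c2cccnc2)cc1`. In this assay compound 1 gives > 100000 nM, which is a limit of the assay and not a number.

Compound 2 `CC(C)(C)c1ccc(OC(=O)c2cn(-c3ccccc3)nc2-c2cccnc2)cc1`. In this assay compound 2 gives > 100000 nM, again a limit.

Compound 3 `O=C(Oc1ccc(-c2ccccc2)cc1)c1cn(-c2ccccc2)nc1-c1cccnc1`. In this assay compound 3 gives > 100000 nM, also a limit.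

Compound 3 therefore stands at the limit of > 100000 nM in this assay, at which 3 of the 3 values shown sit, together with the other two measured compounds; no ranking among the three is possible. The steps among them, a step that the two limits leave unreadable from compound 1 to compound 2, a step that the two limits leave unreadable from compound 1 to compound 3 and a step that the two limits leave unreadable from compound 2 to compound 3, all concern the group on the ester side of the shared core and cannot be sized, since both ends of each step are limits.

Compound 4 `O=C(Oc1ccc(-c2ccccc2)cc1)c1cn(-c2ccccc2)nc1-c1ccncc1` differs from compound 3 by pyridin-4-yl in place of pyridin-3-yl on an aromatic carbon. For the measured compounds named here, none of the measured steps touches this part of the core, so no step bears directly on the change, and the three unreadable steps give no sign that any change so far has moved a value off the limit. The expectation is that compound 4 in this assay also reports a limit, with a step that the limit leaves unreadable from compound 3 to compound 4 as the step implied. Compound 4 is estimated at 150000 nM, within 40000 nM to 600000 nM.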

Compound 4, half-maximal inhibitory concentration: > 100000 nM
Compound 4 ended at the assay's limit; the forecaster's own chance of this, stated with the estimate: 85%; the middle value lies beyond the limit too.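

Compound 4 gives > 100000 nM in this assay, a limit of the assay and not a number. The change from compound 3 to compound 4 therefore yields no readable step: the limit of > 100000 nM in this assay, at which 4 of the 4 values shown sit.

The compounds shown leave open whether any change to this series moves a value off that limit.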